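The compounds below may be only part of what the source reports. "The series", "measured", "known", "first", "only" and "open" are said of these compounds alone.

Within the data shown here, in an ADME assay on the whole organism for inhibition, with Echinochloa crus-galli var. formosensis as the target, with a stated time of 4 days (a lower number here means a stronger inhibitor, a higher number a weaker inhibitor), compound 2 `C[C@H](Nc1nc(Cl)nc(NC(C)(C)C)n1)c1ccccc1` stands at 7410 nM and holds the higher of the two numbers so far. The lower number belongs to compound 1 `CC(C)N(c1nc(Cl)nc(N[C@@H](C)c2ccccc2)n1)C(C)C`, which stands at 110 nM in the same read-out. Compound 3 `CCCCNc1nc(Cl)nc(N[C@@H](C)c2ccccc2)n1` has not yet been measured. Its difference from compound 2 is butyl in place of tert-butyl on a nitrogen on an aromatic ring and the two have the same atoms, joined differently: butyl in place of tert-butyl on a nitrogen on an aromatic ring.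

Among the measured compounds shown here, one measured step bears on this change: a 67-fold higher number from compound 1 to compound 2 (1.83 log units; beyond the scatter) (tert-butylamino in place of diisopropylamino). That step is large and falls on the same substituent, so the numbers in this short series clearly respond to changes there. For the measured compounds named here, it is only a single step, however, and no measured compound carries a straight chain, so the direction is weakly set. A step smaller than that one is expected, leaning towards a lower number. The estimated change is a 2.5-fold lower number from compound 2 to compound 3 (0.39 log units; beyond the scatter) as a working figure. In this assay the estimate for compound 3 is 3000 nM with an expected range from 600 nM to 15000 nM as the working span.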

Compound 3, half-maximal inhibitory concentration: 12900 nM
The estimate for compound 3 lay 4.3-fold (0.63 log units) below the measured number, within the range that was stated.
By their numbers in this assay, from the lowest: compound 1; then compounds 2 and 3 (each within the scatter of the next).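

In this assay, butyl in place of tert-butyl on a nitrogen on an aromatic ring gives a 1.7-fold higher number from compound 2 to compound 3 (0.24 log units; within the scatter), so these two groups of 4 carbon are not told apart at this position in this read-out. The large step from diisopropylamino now appears with a second group, as butylamino in place of diisopropylamino gives a 120-fold higher number from compound 1 to compound 3 (2.07 log units; beyond the scatter); among the three compounds, the low number therefore stands with the diisopropylamino group of compound 1 alone, and not with tert-butylamino or butylamino. Nothing measured here accounts for the difference between diisopropylamino and the other two groups.

The compounds shown leave open whether the low number in compound 1 depends on having two chains on that nitrogen or on the isopropyl groups themselves, a question that diethylamino and isopropylamino would separate. They also leave open how far the number follows the size of the group, which dimethylamino or a longer chain such as hexylamino would begin to show.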